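A few compounds are considered here, and "the series" means these few. Any claim that something is new, unique, unknown or untested is made for them only; others in the source may bear on it.

Compound 1 `CCCCC(O)CC(=O)O[C@H](CC=C(C)C)C1=CC(=O)c2c(O)ccc(O)c2C1=O`: 72200 nM
Compound 2 `CC(=O)OCCC(=O)O[C@H](CC=C(C)C)C1=CC(=O)c2c(O)ccc(O)c2C1=O`: 17300 nM
Compound 3 `CC(=O)OCCO[C@H](CC=C(C)C)C1=CC(=O)c2c(O)ccc(O)c2C1=O`: 41500 nM

Going by the values given here, in a functional assay on HeLa cells (Homo sapiens) for cytotoxicity, read by MTT assay (a lower number here means a stronger inhibitor, a higher number a weaker inhibitor), compound 3 stands second highest of the three numbers; its nearest neighbour is compound 1, at 72200 nM, and only the step of a 2.4-fold higher number from compound 2 to compound 3 (0.38 log units; beyond the scatter) reaches beyond the scatter. Compound 4 `CC(C)=CC[C@@H](OC[C@@H](C)O)C1=CC(=O)c2c(O)ccc(O)c2C1=O` differs from compound 3 in one place: 1-hydroxyethyl in place of acetoxymethyl on a saturated chain carbon bound to an oxygen on a saturated carbon. The measured step that bears on this exchange is a 4.2-fold lower number from compound 1 to compound 2 (0.62 log units; beyond the scatter), where acetoxymethyl replaced 1-hydroxypentyl and the number dropped modestly. Compound 4 makes the opposite kind of exchange, hydroxyl in for acetoxy, so a modest rise in the number is expected, without confidence. Compound 4 is therefore estimated at 80000 nM, between 35000 nM and 200000 nM. The expected step is a 1.9-fold higher number from compound 3 to compound 4 (0.29 log units; within the scatter).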

Compound 4, half-maximal inhibitory concentration: 22500 nM
Compound 4: the middle estimate sits 3.6-fold (0.55 log units) above what was measured, outside the stated range (below it).
By their numbers in this assay, from the lowest: compounds 2, 4, 3 and 1 (each within the scatter of the next, the first and the last beyond it).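

In this assay, 1-hydroxyethyl can stand in place of acetoxymethyl with the result staying within the scatter (a 1.8-fold lower number from compound 3 to compound 4 (0.27 log units; within the scatter)), so the acetoxy ester is not required at this saturated chain carbon. The 2-hydroxypropyl group also holds level with (2-acetoxyethyl)carbonyl (a 1.3-fold higher number from compound 2 to compound 4 (0.11 log units; within the scatter)), while in place of (2-hydroxyhexyl)carbonyl it gives a clear drop (a 3.2-fold lower number from compound 1 to compound 4 (0.51 log units; beyond the scatter)). No supporting measurement is available to explain these results.

Still open, going by these compounds, is how an amine, a carboxylic acid or a longer chain bearing the hydroxyl would read here. Also open, on these data alone, is whether the opposite stereocentre in 2-hydroxypropyl would give the same number.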